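The compounds below may be only part of what the source reports. "The series", "measured", "known", "first", "only" and "open" are said of these compounds alone.

Measured in a functional assay on NCI-H460 cells (Homo sapiens) for inhibition, read by sulforhodamine B assay, with a stated time of 48 h; on this read-out lower numbers stand for stronger inhibition of growth and higher numbers for weaker inhibition of growth:

- Compound 1 `COc1ccc(C(=O)C2=CCCCc3c2cc(OC)c(OC)c3OC)c(O)c1O`: > 10000 nM, a limit
- Compound 2 `COc1ccc(C(=O)C2=CCCc3c2cc(OC)c(OC)c3OC)c(O)c1O`: 2800 nM
- Compound 3 `COc1ccc(CC2CCCCc3c2cc(OC)c(OC)c3OC)c(O)c1O`: > 10000 nM, a limit

Compound 2 is the only one of the three with a true number, 2800 nM. Compound 1 and compound 3 report only a limit, as the limit of > 10000 nM in this assay, at which 2 of the 3 values shown sit, shows. Compound 2 therefore has no measured neighbour to be compared with step by step.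

The next compound, compound 4 `COc1ccc(C(=O)C2=CCCc3c2cc(OC)c(OC)c3OC)cc1O`, keeps the core of compound 2 and changes one thing: hydrogen in place of hydroxy on an aromatic carbon. That carbon is a ring position ortho to a hydroxy group, ortho to a large group and meta to a methoxy group.

No measured pair among these compounds isolates a change of this kind, so any forecast is uncertain. With compound 2 at 2800 nM as the only anchor, a moderate move towards stronger inhibition in this assay is expected, though a result near compound 2 would be no surprise. The expected change is a 3.1-fold lower number from compound 2 to compound 4 (0.49 log units; beyond the scatter). For compound 4 the estimated value is 900 nM, with an expected range of 120 nM to 5000 nM.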

Compound 4, concentration for 50% growth inhibition: 6000 nM
For compound 4 the middle estimate is 6.7-fold (0.82 log units) below the measured one; the measured number lies above the stated range.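

Swapping the hydroxy group for hydrogen on this aromatic carbon gives, in this assay, a 2.1-fold higher number from compound 2 to compound 4 (0.33 log units; beyond the scatter), a modest weakening of growth inhibition. The hydroxy group at this place, ortho to a hydroxy group, ortho to a large group and meta to a methoxy group, therefore goes with stronger inhibition in this pair, yet its loss does not abolish the effect, as compound 4 still gives a true number of 6000 nM. This is the first change in the series whose size can be read, because the other compounds offer no number for such a comparison: the limit of > 10000 nM in this assay, at which 2 of the 4 values shown sit.

From the compounds shown here alone, what remains open is whether any replacement at this carbon would weaken inhibition, or whether an amine or a fluorine atom there would match the hydroxy group of compound 2. Within the data shown here, the single pair also cannot tell why the number rises, or whether the remaining hydroxy group on the same ring matters to a similar degree.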